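The source may report more compounds than this note shows. Statements on the series, on what has been measured and on what is new or still open speak of the compounds shown alone.

Working notes on the series. Three compounds have been run in an ADME assay on L02 cells (Homo sapiens) for inhibition, read by CCK-8 assay, with a stated time of 48 h (a higher number here means a weaker inhibitor of growth, a lower number a stronger inhibitor of growth), all built on a shared core with a chloropyrimidine diamine pattern seen in compound 1 `Cc1ccccc1Nc1nc(NC2CCCCC2)ncc1Cl`, compound 2 `Cc1ccccc1Nc1nc(Nc2ccc(N3CCCCC3)cc2)ncc1Cl` and compound 3 `CN1CCN(c2ccc(Nc3ncc(Cl)c(Nc4ccccc4)n3)nc2)CC1`.

Compound 1 reaches only the limit of this assay: its reported value of > 100000 nM is a limit, not a number (the limit of > 100000 nM in this assay, at which 1 of the 3 values shown sits). Compound 2 gives 5690 nM in this assay. Compound 3 gives 7990 nM in this assay. Between compound 2 and compound 3 the gap lies within the scatter of repeated runs, so the two numbers show the same effect on growth and no order between them is drawn. Compound 1 stands apart only as a limit.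

Compound 4 `Cc1ccc(Nc2nc(Nc3ccc(N4CCN(C)CC4)cn3)ncc2Cl)cc1` is the next entry and is not yet measured. It differs from compound 3 in one place: methyl in place of hydrogen on an aromatic carbon. Within the data shown here, no pair of measured compounds carries this same change, so there is no measured step to lean on, and the expectation rests on compound 3 alone. The step is expected to be small, a 1.0-fold higher number from compound 3 to compound 4 (0.00 log units; within the scatter), with no direction beyond the scatter.

Compound 4 is therefore estimated at 8000 nM in this assay, in the range 3000 nM to 25000 nM.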

Compound 4, concentration for 50% growth inhibition: 13900 nM
The estimate for compound 4 lay 1.7-fold (0.24 log units) below the measured number, and the stated range covers the measured number.
By their numbers in this assay, from the lowest: compounds 2, 3 and 4 (each within the scatter of the next, the first and the last beyond it). At a limit, above all of these: compound 1.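

In this assay, the change from phenyl to 4-methylphenyl gives a 1.7-fold higher number from compound 3 to compound 4 (0.24 log units; within the scatter), so a methyl on this six-membered aromatic ring of carbon only, para to a large group, leaves the two compounds with the same effect on growth. Among these compounds, this is the first pair that differs in one place, and it gives the first measured step: the earlier compounds offered no such comparison and could say nothing about this position. No measured information shown bears on this step, and nothing here accounts for its size.

Going by these compounds, the position has been probed with methyl alone, and it remains open whether a larger or different group there, such as a methoxy group, a carboxylic acid, an amine or a longer chain, would move the number beyond the scatter. Among the compounds shown here, this pair is also the only one carrying the change, so it remains open whether methyl in place of hydrogen reads the same way on other members.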